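This account rests on a few compounds, and the source may have more. Where it says the series, first, only, none or still open, it means among the compounds named here.

Of the compounds shown here, three have so far been tested in a functional assay on the whole organism (strain albino) for inhibition, with Rattus norvegicus as the target, read by paw edema, with stated times of 1 h and 0.5 h, at a dose of 100 mg/kg by the oral route; a higher number here means more inhibition at the dose given (going by the name of the read-out), a lower number less inhibition. Compound 1 `O=C(CSc1nc(-c2ccc(Cl)cc2)c(C(=O)O)c(=O)[nH]1)Nn1c(COc2ccc(Cl)cc2Cl)nc2ccccc2c1=O` gives 51.9% in this assay. Compound 2 `O=C(CSc1nc(-c2ccc(O)cc2)c(C(=O)O)c(=O)[nH]1)Nn1c(COc2ccc(Cl)cc2Cl)nc2ccccc2c1=O` shares the core of compound 1 and differs from it in one place, (hydroxy in place of chloro on an aromatic carbon). In this assay compound 2 gives 32.7%, so the step is a number 19.2 percentage points lower from compound 1 to compound 2 (beyond the scatter). Compound 3 `Cn1c(SCC(=O)Nn2c(COc3ccc(Cl)cc3Cl)nc3ccccc3c2=O)nc(-c2ccc(Cl)cc2)c(C#N)c1=O` is built on a different core, and the difference between the two cores is not broken down here. In this assay compound 3 gives 80.8%, the highest of the three values and beyond the scatter from both of the others.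

Compound 4 `Cn1c(SCC(=O)Nn2c(COc3ccc(Cl)cc3Cl)nc3ccccc3c2=O)nc(-c2ccc(O)cc2)c(C#N)c1=O` has not yet been measured. It differs from compound 3 in one place, (hydroxy in place of chloro on an aromatic carbon). This is the same change that turns compound 1 into compound 2, now made on the other core, and the place is described in the same words for both pairs. Because the step of a number 19.2 percentage points lower from compound 1 to compound 2 (beyond the scatter) was a modest drop, the step expected here is a number 18.8 percentage points lower from compound 3 to compound 4 (beyond the scatter). That expectation rests on a single earlier pair on a different core, so the range allowed around it is wide. Compound 4 is therefore expected to give about 62% in this assay, with a likely span from 48% to 76%.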

Compound 4, a percentage reported as inhibition, in the whole organism at one dose (the size of the read-out at that dose, not a potency): 76.9%
The estimate for compound 4 lay 14.9 percentage points below the measured number; measured number outside the range, above it.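

In this assay, putting 4-hydroxyphenyl in place of 4-chlorophenyl on the second core gives a number 3.9 percentage points lower from compound 3 to compound 4 (within the scatter), so on this core the swap leaves the read-out essentially where it was. The change therefore does not carry over with the same size from one core to the other, and a step measured on one core is a poor guide to the step on the other: the same change on two cores in this assay, a number 19.2 percentage points lower (beyond the scatter) from compound 1 to compound 2 and a number 3.9 percentage points lower (within the scatter) from compound 3 to compound 4, 15.3 percentage points apart, beyond the scatter of two such steps. This does not show why the two steps differ, which part of the cores is responsible, or which of the two sizes is more typical, as it rests on just two pairs measured at a single dose.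

From the compounds shown here alone, only chloro and hydroxy appear at this place on the aromatic ring, so it remains open how a methoxy, a fluoro or an amine there would behave on either core. Going by these compounds, it is also open whether the contrast between the cores would persist with a change elsewhere in the molecule, such as a longer chain in place of the sulfur-linked acetamide link, or whether it is particular to this one swap.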